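From bromo to amino on an aromatic carbon

The source may hold more compounds than are shown below. What is called first, only, known or untested is meant among the compounds shown, and "the series" means these compounds.

Measured in a functional assay on the whole organism with Mus musculus as the target; on this read-out lower numbers stand for an effect already at smaller amounts and higher numbers for an effect only at larger amounts of compound:
- compound 1 `COc1cc2c(cc1OC)C(c1ccc([N+](=O)[O-])cc1)=NN=C(S)C2`: 69.8 umol/kg
- compound 2 `COc1cc2c(cc1OC)C(c1ccc(Br)cc1)=NN(C)C(=S)C2`: 60.4 umol/kg
- compound 3 `COc1cc2c(cc1OC)C(c1ccc([N+](=O)[O-])cc1)=NNC(=O)C2`: > 120 umol/kg (a limit, not a number)

Compound 2 gives 60.4 umol/kg and compound 1 gives 69.8 umol/kg, two values within the usual scatter of each other, so neither can be ranked ahead. Compound 3 reaches only a limit, > 120 umol/kg, so it offers no exact number for comparison.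

Compound 4 `COc1cc2c(cc1OC)C(c1ccc(N)cc1)=NN(C)C(=S)C2` is compound 2 with amino in place of bromo on an aromatic carbon, para to a large group (amino in place of bromo on an aromatic carbon). Within the data shown here, no measured pair shows this exchange on its own, so the expectation starts from compound 2 at 60.4 umol/kg and remains uncertain. In this assay, a small move toward a lower number is expected, not clearly beyond the scatter: a 1.5-fold lower number from compound 2 to compound 4 (0.18 log units; within the scatter). For compound 4 the estimate is 40 umol/kg, with an expected range from 14 umol/kg to 100 umol/kg.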

Compound 4, dose for half-maximal effect: 20.3 umol/kg
Compound 4: the middle estimate sits 2.0-fold (0.29 log units) above what was measured; the range from low to high includes it.
By their numbers in this assay, from the lowest: compound 4; then compounds 2 and 1 (each within the scatter of the next). At a limit, above all of these: compound 3.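

Going from 4-bromophenyl to 4-aminophenyl in this assay gives a 3.0-fold lower number from compound 2 to compound 4 (0.47 log units; beyond the scatter), the first step in this set that can be read as one change in one place. It shows that this aromatic carbon, para to a large group, is not a silent spot: the group placed there can shift the dose beyond the usual scatter. The amino group brings a hydrogen-bond donor and a hydrogen-bond acceptor that bromo lacks, but nothing given here says whether these explain the shift.

The compounds shown leave open whether the lower number belongs to the amino group itself or would also appear with a hydroxyl or dimethylamino group on the same carbon. They also leave open whether the same exchange would give a similar step on the core of compound 1 or compound 3.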